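Series notes: aryl-to-methyl exchange on the shared core

This account rests on a few compounds, and the source may have more. Where it says the series, first, only, none or still open, it means among the compounds named here.

The three measured compounds share one core and differ only in the group carried on a single aromatic carbon. Compound 1 `Cc1nc2c3ccccc3ccc2c2nc3c(ccc4ccccc43)c(-c3cccnc3)c12` gives 63.6 ug/mL in a functional assay, read by spectrophotometry, with a stated time of 15 min; on this read-out higher numbers stand for weaker inhibition and lower numbers for stronger inhibition. Compound 2 `Cc1nc2c3ccccc3ccc2c2nc3c(ccc4ccccc43)c(-c3ccccc3N)c12` gives 45.6 ug/mL in this assay. Compound 3 `Cc1ccc(-c2c3ccc4ccccc4c3nc3c2c(C)nc2c4ccccc4ccc32)cc1` gives 68.7 ug/mL in this assay, the highest of the three numbers, though its steps to the others are small: a 1.1-fold higher number from compound 1 to compound 3 (0.03 log units; within the scatter) and a 1.5-fold higher number from compound 2 to compound 3 (0.18 log units; within the scatter); the remaining step is a 1.4-fold lower number from compound 1 to compound 2 (0.14 log units; within the scatter). None of these steps lies beyond the scatter, so no order among the three can be drawn.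

Compound 4 `Cc1nc2c3ccccc3ccc2c2nc3c(ccc4ccccc43)c(C)c12` is not yet measured. It differs from compound 3 by methyl in place of 4-methylphenyl on an aromatic carbon. For the measured compounds named here, the three measured steps each exchange one six-membered aromatic ring for another and all stay within the scatter; none removes the ring altogether, so no measured step bears directly on this change. With only that to go on, the step of a 1.0-fold higher number from compound 3 to compound 4 (0.01 log units; within the scatter) is expected to be small, with a wide range. Compound 4 is therefore estimated at 70 ug/mL in this assay, between 30 ug/mL and 160 ug/mL.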

Compound 4, half-maximal inhibitory concentration: 89.6 ug/mL
Beside the measured number, compound 4's estimate is 1.3-fold (0.11 log units) below it; measured number inside the range.
By their numbers in this assay, from the lowest: compounds 2, 1, 3 and 4 (each within the scatter of the next).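

For the compounds shown here, exchanging the 4-methylphenyl for methyl, the first change here that removes the six-membered aromatic ring from this aromatic carbon opposite the ring nitrogen, stays within the scatter in this assay (with a 1.3-fold higher number from compound 3 to compound 4 (0.12 log units; within the scatter)). The same holds against the other two aryl groups (with a 1.4-fold higher number from compound 1 to compound 4 (0.15 log units; within the scatter) and with a 2.0-fold higher number from compound 2 to compound 4 (0.29 log units; within the scatter)), so across compounds 1 to 4 the ring at this position is not needed to keep the number in this range, although the step from the 2-aminophenyl compound is the largest of the three. The data shown offer no explanation for this flat response.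

Whether this position can respond at all remains open, since every group shown, from methyl to the aryl rings, gives numbers within the scatter of its neighbour in the order. An amine or a carboxylic acid on this carbon, or a longer alkyl chain, would test whether anything other than an aryl ring or methyl moves the number beyond the scatter.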